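Benzylamide chloro pattern on the shared core: compound 4 ahead

The source may report more compounds than this note shows. Statements on the series, on what has been measured and on what is new or still open speak of the compounds shown alone.

Measured in an assay on brain for inhibition of Fatty-acid amide hydrolase 1 (Rattus norvegicus), read by scintillation counting, with a stated time of 10 min (a higher number here means a weaker inhibitor, a lower number a stronger inhibitor), so far:
compound 1, `CC(C)Cc1ccc(C(C)C(=O)NCc2ccc(Cl)cc2)cc1`: 27000 nM
compound 2, `COc1ccccc1CNC(=O)C(C)c1ccc(CC(C)C)cc1`: 18000 nM
compound 3, `CC(C)Cc1ccc(C(C)C(=O)NCc2ccccc2Cl)cc1`: 4100 nM

Compound 3 stands lowest of the three numbers in this assay. Both steps toward it lie beyond the scatter: a 6.6-fold lower number from compound 1 to compound 3 (0.82 log units; beyond the scatter) and a 4.4-fold lower number from compound 2 to compound 3 (0.64 log units; beyond the scatter), whereas a 1.5-fold lower number from compound 1 to compound 2 (0.18 log units; within the scatter) lies within it.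

The next compound, compound 4 `CC(C)Cc1ccc(C(C)C(=O)NCc2ccc(Cl)cc2Cl)cc1`, differs from compound 3 by chloro in place of hydrogen on an aromatic carbon. The step that bears on this is a 6.6-fold lower number from compound 1 to compound 3 (0.82 log units; beyond the scatter): compound 1 carries the 4-chlorophenyl group alone and compound 3 the 2-chlorophenyl group alone, and compound 4 combines the two. For the measured compounds named here, no measured step adds a second chloro to a ring already carrying one, so nothing shows whether the gain seen in compound 3 survives or whether the weaker showing of compound 1 returns in part. The expected outcome is a step of modest size at most, slightly toward a higher number, a 1.5-fold higher number from compound 3 to compound 4 (0.17 log units; within the scatter). Compound 4 is therefore estimated at 6000 nM in this assay, with a range from 2000 nM to 18000 nM.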

Compound 4, half-maximal inhibitory concentration: 21000 nM
Compound 4: middle estimate off by 3.5-fold (0.54 log units), on the low side, outside the stated range (above it).
By their numbers in this assay, from the lowest: compound 3; then compounds 2, 4 and 1 (each within the scatter of the next).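

In this assay, chloro in place of hydrogen on the ring carbon para to a large group, turning 2-chlorophenyl into 2,4-dichlorophenyl, gives a 5.1-fold higher number from compound 3 to compound 4 (0.71 log units; beyond the scatter), so the lower number of compound 3 does not carry over to the dichloro ring. The other two steps, a 1.3-fold lower number from compound 1 to compound 4 (0.11 log units; within the scatter) and a 1.2-fold higher number from compound 2 to compound 4 (0.07 log units; within the scatter), both lie within the scatter, which means the two chloro groups do not add up: with chloro already at this position, a second chloro on the ring brings no gain beyond compound 1. Nothing available accounts for this loss.

Going by these compounds, whether fluoro, methyl or hydroxyl at this ring carbon would cost as much as chloro remains open. So does whether the loss holds when the 2-chloro group is replaced by 2-methoxy.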